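Sulfur substituent change in a ribosylated series

A few compounds are considered here, and "the series" means these few. Any claim that something is new, unique, unknown or untested is made for them only; others in the source may bear on it.

Compound 1 `CSc1[nH]ccc2ncnc1-2` and compound 2 `OC[C@H]1OC(n2cnc3c(SCc4ccccc4)nccc32)[C@H](O)[C@@H]1O` have both been run in a functional assay on the whole organism (Pleural cavity) with Rattus norvegicus as the target; a lower number here means that less compound is needed, a higher number that more compound is needed for the effect. In this assay compound 1 gives 9 mg/kg. In this assay compound 2 gives 9 mg/kg, level with compound 1 within the scatter. Compound 3 `OC[C@H]1OC(n2cnc3c(S)nccc32)[C@H](O)[C@@H]1O` is not yet measured in this assay. It differs from compound 2 by hydrogen in place of benzyl on a sulfur. For the measured compounds named here, no measured pair shows this change alone, so its size in this assay is open. A small step toward more compound needed is expected, a 1.4-fold higher number from compound 2 to compound 3 (0.16 log units; within the scatter), within or just beyond the scatter. Compound 3 is expected to give about 13 mg/kg in this assay, with a range from 5 mg/kg to 35 mg/kg.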

Compound 3, dose for half-maximal effect: 9 mg/kg
Estimate against measurement, compound 3: 1.4-fold (0.16 log units) above; the measured number falls inside the stated range.
By their numbers in this assay, from the lowest: compounds 1, 2 and 3 (each within the scatter of the next).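

In this assay, for the compounds shown here, the single change on the sulfur gives no change at the digits printed from compound 2 to compound 3 (within the scatter) in this first pair that differs in one place only. The benzyl group, with its six-membered aromatic ring, is therefore not required for the dose read-out in this pair, and a free sulfanyl group serves equally well. Nothing available bears on why the two compounds agree. Still open, on these data alone, is whether the sulfur itself is needed, which an amine in place of the sulfanyl group would test. A longer chain on the sulfur, such as n-butyl, or a carboxylic acid at its end, would show how much variation this place tolerates.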